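Dimethylamide to acetylpiperidinyl amide on a pyrazine core

The source may report more compounds than this note shows. Statements on the series, on what has been measured and on what is new or still open speak of the compounds shown alone.

Compound 1 `CN(C)S(=O)(=O)c1ccccc1Nc1cc(-c2ccc3ccn(C)c3c2)c2nccnc2c1` and compound 2 `CN(C)C(=O)c1ccncc1Nc1cc(-c2ccc3ccn(C)c3c2)c2nccnc2c1` share a core and differ in the group carried on it. In an assay for inhibition of 6-phosphofructo-2-kinase/fructose-2,6-bisphosphatase 3 (Homo sapiens), read by ADP-Glo, with a stated time of 2 h (a higher number here means a weaker inhibitor, a lower number a stronger inhibitor), compound 1 gives 94 nM, while compound 2 gives 499 nM, the higher of the two numbers and a gap that lies beyond the usual scatter. Compound 3 `CC(=O)N1CCCC(NC(=O)c2ccncc2Nc2cc(-c3ccc4ccn(C)c4c3)c3nccnc3c2)C1` follows from compound 2 by (1-acetylpiperidin-3-yl)amino in place of dimethylamino on a carbonyl carbon. Within the data shown here, no measured pair shows a change of this kind, so the direction is open; the step of a 1.2-fold lower number from compound 2 to compound 3 (0.10 log units; within the scatter) is expected to be modest and close to the scatter. Compound 3 is expected to give 400 nM, between 120 nM and 1500 nM.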

Compound 3, half-maximal inhibitory concentration: 11 nM
Beside the measured number, compound 3's estimate is 36-fold (1.56 log units) above it; the whole stated range lies above it.
By their numbers in this assay, from the lowest: compound 3; then compound 1; then compound 2.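

In this assay, (1-acetylpiperidin-3-yl)amino in place of dimethylamino on a carbonyl carbon gives a 45-fold lower number from compound 2 to compound 3 (1.66 log units; beyond the scatter), so the number responds strongly to the group at this position. The entering group brings a six-membered non-aromatic ring, an acetyl group and an amide hydrogen, and this single step does not separate their contributions. Nothing available bears on the reason for the drop.

As far as these compounds go, it remains open whether a piperidine with a free ring amine, or a cyclohexyl group, would serve as well. From the compounds shown here alone, whether the acetyl carbonyl matters, and whether a longer chain in its place would change the number, also remains open.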